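Aryl swap on the chain carbon of compound 1

The compounds below may be only part of what the source reports. "The series", "measured", "known", "first", "only" and "open" are said of these compounds alone.

Compound 1 `O=C(O)c1ccc(C(=O)/C(=C\c2ccc(F)c([N+](=O)[O-])c2)SCc2ccc(Cl)cc2)cc1`: in a functional assay on DU-145 cells (Homo sapiens) for inhibition, read by trypan blue exclusion, with a stated time of 96 h (a higher number here means a weaker inhibitor of growth, a lower number a stronger inhibitor of growth), compound 1 gives 50000 nM.
Compound 2 `O=C(O)c1ccc(C(=O)/C(=C\c2ccc(F)c([N+](=O)[O-])c2)SCc2ccc(C(F)(F)F)cc2)cc1`: in this assay compound 2 gives 1000 nM.

Compound 1 holds the highest number of the two measured; its nearest neighbour is compound 2, with a 50-fold lower number from compound 1 to compound 2 (1.70 log units; beyond the scatter). Compound 3 `CSc1ccc(/C=C(/SCc2ccc(Cl)cc2)C(=O)c2ccc(C(=O)O)cc2)cc1` differs from compound 1 by 4-(methylsulfanyl)phenyl in place of 4-fluoro-3-nitrophenyl on a double-bonded chain carbon bound to a double-bonded chain carbon. Within the data shown here, the single measured step, a 50-fold lower number from compound 1 to compound 2 (1.70 log units; beyond the scatter), alters a substituent on an aromatic carbon and leaves the chain position untouched, so no measured step bears on the change to compound 3. No direction is therefore expected beyond the scatter, and the range must be wide. For compound 3 the estimate in this assay is 30000 nM, within 3000 nM to 100000 nM. The expected step is a 1.7-fold lower number from compound 1 to compound 3 (0.22 log units; within the scatter).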

Compound 3, concentration for 50% growth inhibition: > 100000 nM
Compound 3: no number, only a limit (the forecaster's own chance of this, stated with the estimate: 30%); middle value at least 3.3-fold (0.52 log units) away from the limit.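

At the double-bonded chain carbon bound to a double-bonded chain carbon, 4-(methylsulfanyl)phenyl in place of 4-fluoro-3-nitrophenyl gives an at least 2.0-fold higher number from compound 1 to compound 3 (0.30 log units; that floor lies within the scatter) in this assay. This change at the chain position therefore brings no gain in growth inhibition, although the size of the loss cannot be fixed. Compound 3 gives a limit of the assay and not a number: the limit of > 100000 nM in this assay, at which 1 of the 3 values shown sits.

Open, on these data alone, is whether trifluoromethyl in place of chloro would also lower the number with 4-(methylsulfanyl)phenyl at the chain carbon. Also open, as far as these compounds go, is how a phenyl bearing an amine would read at this position.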